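This account rests on a few compounds, and the source may have more. Where it says the series, first, only, none or still open, it means among the compounds named here.

In a functional assay on A549 cells (Homo sapiens), read by sulforhodamine B assay, with a stated time of 5 days (a higher number here means a weaker inhibitor of growth, a lower number a stronger inhibitor of growth), compound 1 (`OC[C@H]1O[C@@H](n2cc(F)c3c(-c4cccs4)ncnc32)[C@H](O)[C@@H]1O`) gives 61 nM as its reading. Compound 2 (`OC[C@H]1O[C@@H](n2cc(Cl)c3c(-c4ccco4)ncnc32)[C@H](O)[C@@H]1O`) shows > 10000 nM as its entry, and that is a limit of the assay and not a number. Compound 3 (`OC[C@H]1O[C@@H](n2cc(Cl)c3c(-c4cccs4)ncnc32)[C@H](O)[C@@H]1O`) is compound 2 with one change (thiophen-2-yl in place of furan-2-yl on an aromatic carbon): thiophen-2-yl in place of furan-2-yl on an aromatic carbon. For the measured compounds named here, no measured pair shows this swap alone, so its size cannot be read directly from the data. Going by the values given here, compound 1 also carries thiophen-2-yl and, with 61 nM as its reading in this assay for growth inhibition, is the only guide here. A large step toward stronger growth inhibition is therefore expected, far beyond the usual scatter, with an estimated change (an at least 100-fold lower number from compound 2 to compound 3 (2.00 log units; beyond the scatter)) that rests on this single comparison. Compound 3 is expected to read 100 nM (estimated range 20 nM to 800 nM).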

Compound 3, concentration for 50% growth inhibition: 380 nM
The estimate for compound 3 lay 3.8-fold (0.58 log units) below the measured number; measured number inside the range.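

In this assay, with the chloro group held fixed, thiophen-2-yl in place of furan-2-yl gives an at least 26-fold lower number from compound 2 to compound 3 (1.42 log units; beyond the scatter), which is a direct reading of this swap on its own at this aromatic carbon. That step is only a minimum, because compound 2 sits at a limit of the assay and not at a number: the limit of > 10000 nM in this assay, at which 1 of the 3 values shown sits. With thiophen-2-yl held fixed, chloro in place of fluoro gives a 6.2-fold higher number from compound 1 to compound 3 (0.79 log units; beyond the scatter), so the reading also shifts with the halogen on the shared core.

For the compounds shown here, only two five-membered aromatic rings appear at this position, so it remains open whether a phenyl ring, an amine or a longer chain there would keep growth inhibition. From the compounds shown here alone, whether the furan-2-yl to thiophen-2-yl swap has the same size with fluoro on the core also stays open.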